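The source may report more compounds than this note shows. Statements on the series, on what has been measured and on what is new or still open speak of the compounds shown alone.

Working notes on the series. In an ADME assay on PC-3 cells (Homo sapiens) for cytotoxicity, read by WST assay, tested at 100 uM (a higher number here means more inhibition at the concentration tested (going by the name of the read-out), a lower number less inhibition), compound 1 `COC(=O)c1cccc(NC(=O)C2CCCN(C(=O)c3cc(C(F)(F)F)cc(C(F)(F)F)c3)C2)c1` gives 0%. Compound 2 `CSc1cccc(C(=O)N2CCCC(C(=O)Nc3ccc(Cl)cc3)C2)c1` gives 0% in this assay, and compound 3 `O=C(Nc1ccc(Cl)cc1)C1CCCN(C(=O)c2cc(C(F)(F)F)cc(C(F)(F)F)c2)C1` gives 14%. Compound 1 thus stands level with compound 2 at the digits given, the two together being the lowest of the three numbers; its nearest neighbour is compound 2, without change beyond the scatter, and its furthest is compound 3, which lies higher by a number 14 percentage points higher from compound 1 to compound 3 (beyond the scatter).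

The step to compound 4 `O=C(Nc1cccc(Oc2nccc(C(F)(F)F)c2Cl)c1)C1CCCN(C(=O)c2cc(C(F)(F)F)cc(C(F)(F)F)c2)C1` is (3-chloro-4-(trifluoromethyl)pyridin-2-yl)oxy in place of methoxycarbonyl on an aromatic carbon. Among the measured compounds shown here, the only measured step that bears on it is the one from compound 1 to compound 3, which also replaced the group on the aryl ring of the amide-type nitrogen and gave a modest rise, a number 14 percentage points higher from compound 1 to compound 3 (beyond the scatter). Nothing measured shows the effect of the entering group itself. On that slim basis a small upward step is expected, a number 12 percentage points higher from compound 1 to compound 4 (beyond the scatter), and compound 4 is estimated at 12%, within 0% to 35%.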

Compound 4, a percentage reported as inhibition, at one concentration (the size of the read-out at that concentration, not a potency): 0%
Compound 4: middle estimate off by 12 percentage points, on the high side; the measured number falls inside the stated range.
By their numbers in this assay, from the lowest: compounds 1, 2 and 4 (each within the scatter of the next); then compound 3.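

In this assay, exchanging the methoxycarbonyl group, with 4 heavy atoms and no ring, for the (3-chloro-4-(trifluoromethyl)pyridin-2-yl)oxy group, with 12 heavy atoms and a six-membered aromatic ring, gives no change at the digits printed from compound 1 to compound 4 (within the scatter). This aromatic carbon, meta to a large group, therefore takes a much larger substituent with no read-out change beyond the scatter, so a change on this aryl ring does not by itself repeat a number 14 percentage points higher from compound 1 to compound 3 (beyond the scatter). No measurement available accounts for this result.

Open, as far as these compounds go, is whether an amine or a carboxylic acid on this aromatic carbon would move the number away from that of compound 1. Also open, from the compounds shown here alone, is whether a smaller ether such as methoxy here would behave like the (3-chloro-4-(trifluoromethyl)pyridin-2-yl)oxy group.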